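Moving the fluorine on compound 1: working notes

The source may hold more compounds than are shown below. What is called first, only, known or untested is meant among the compounds shown, and "the series" means these compounds.

- compound 1 `COc1ccc(/C=C/C(=O)c2cccc(-c3ccc(F)cc3)c2)cc1` gives 11200 nM
- compound 2 `COc1cc(/C=C/C(=O)c2ccc(N)c(-c3ccc(F)cc3)c2)ccc1O` gives 12200 nM

Both values come from a functional assay on A549 cells (Homo sapiens) for cytotoxicity, read by sulforhodamine B assay, with a stated time of 48 h (on this read-out higher numbers stand for weaker inhibition and lower numbers for stronger inhibition), and lie within the scatter of each other, so compound 1 stands level with compound 2 on these numbers. Compound 3 `COc1ccc(/C=C/C(=O)c2cccc(-c3cccc(F)c3)c2)cc1` has 3-fluorophenyl in place of 4-fluorophenyl on an aromatic carbon. Within the data shown here, no measured step tests this change, so the only anchor is compound 1 at 11200 nM, and no step beyond the scatter is expected in this assay. The estimated step is a 1.1-fold higher number from compound 1 to compound 3 (0.03 log units; within the scatter). Compound 3 is expected at 12000 nM, with an estimated range of 6000 nM to 25000 nM.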

Compound 3, half-maximal inhibitory concentration: 2440 nM
The estimate for compound 3 lay 4.9-fold (0.69 log units) above the measured number, and the stated range ends above it.
By their numbers in this assay, from the lowest: compound 3; then compounds 1 and 2 (each within the scatter of the next).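

Within this assay 3-fluorophenyl in place of 4-fluorophenyl gives a 4.6-fold lower number from compound 1 to compound 3 (0.66 log units; beyond the scatter) and so shows that the place of the fluorine on this ring alone can move the number beyond the scatter, which the earlier pair, differing in more than one place, could not show. Heavy atoms, donors and acceptors stay the same in this change. Nothing at hand accounts for the step.

Open, from the compounds shown here alone, is whether a chlorine, a methoxy group or an unsubstituted phenyl would give a similar number. Also open, going by these compounds, is whether 3-fluorophenyl brings a similar step on the core of compound 2.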